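Propoxy replacing cyclohexyloxy on a nitroaryl sulfonamide

A few compounds are considered here, and "the series" means these few. Any claim that something is new, unique, unknown or untested is made for them only; others in the source may bear on it.

Measured so far in an assay on SK-BR-3 cells for inhibition of Aromatase (Homo sapiens); on this read-out lower numbers stand for stronger inhibition and higher numbers for weaker inhibition:
compound 1, `CCCOc1cc([N+](=O)[O-])ccc1NS(C)(=O)=O`, gives 2510 nM;
compound 2, `CCCCCCOc1cc([N+](=O)[O-])ccc1NS(C)(=O)=O`, gives 2670 nM;
compound 3, `CN(c1ccc([N+](=O)[O-])cc1OC1CCCCC1)S(C)(=O)=O`, gives 470 nM.

Compound 3 holds the lowest number of the three, and its gaps to compound 1 and to compound 2 lie beyond the scatter. Compound 4, `CCCOc1cc([N+](=O)[O-])ccc1N(C)S(C)(=O)=O`, is not yet measured. It differs from compound 3 by propyl in place of cyclohexyl on an oxygen on an aromatic ring. Within the data shown here, the only measured step of a single change, a 1.1-fold higher number from compound 1 to compound 2 (0.03 log units; within the scatter), altered the alkoxy chain and moved nothing beyond the scatter, which speaks for the size of the alkoxy group mattering little. Compound 3 also carries a methyl on the sulfonamide nitrogen that compounds 1 and 2 lack, so the gap between compound 3 and compound 1 cannot be assigned to the alkoxy group alone; compound 4 keeps that methyl. For compound 4 a modest weakening is therefore expected, estimated as a 1.9-fold higher number from compound 3 to compound 4 (0.28 log units; within the scatter), giving an expected value of 900 nM with a range from 300 nM to 2700 nM.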

Compound 4, half-maximal inhibitory concentration: 760 nM
Estimate against measurement, compound 4: 1.2-fold (0.07 log units) above; measured number inside the range.
By their numbers in this assay, from the lowest: compounds 3 and 4 (each within the scatter of the next); then compounds 1 and 2 (each within the scatter of the next).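

In this assay, propoxy in place of cyclohexyl on the oxygen gave a 1.6-fold higher number from compound 3 to compound 4 (0.21 log units; within the scatter), so with the methyl on the sulfonamide nitrogen present, this change at the oxygen stays within the scatter. Methyl in place of hydrogen on the sulfonamide nitrogen gave a 3.3-fold lower number from compound 1 to compound 4 (0.52 log units; beyond the scatter), making the nitrogen, not the oxygen, the one place among these compounds where a single change has moved the number beyond the scatter. Nothing available explains why either change has the size it has.

Whether the nitrogen methyl gives a similar step alongside cyclohexyloxy or hexyloxy stays open, since the compounds shown give that step with propoxy alone. Also open, on these data alone, is what an ethyl on the sulfonamide nitrogen, or an alkoxy chain carrying an amine, would do to the number.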